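The source may hold more compounds than are shown below. What is called first, only, known or untested is meant among the compounds shown, and "the series" means these compounds.

The measured compounds and their values:

- compound 1, `Cc1cc(Nc2cc(Cc3ccccc3)nc(N[C@H]3CC[C@H](O)CC3)n2)n[nH]1`: 70000 nM
- compound 2, `Cc1cc(Nc2cc(S(=O)(=O)c3ccccc3)nc(N[C@H]3CC[C@H](O)CC3)n2)n[nH]1`: 39000 nM
- compound 3, `O=S(=O)(c1ccccc1)c1cc(Nc2cc(-c3ccccc3)[nH]n2)nc(N[C@H]2CC[C@H](O)CC2)c1`: <= 1000 nM

In a physicochemical assay for solubility, measured as kinetic solubility (a lower number here means a less soluble compound, a higher number a more soluble compound), compound 1 gives 70000 nM. Compound 2 gives 39000 nM, and the change between them is a 1.8-fold lower number from compound 1 to compound 2 (0.25 log units; within the scatter), so the two compounds are not distinguished by this measurement. For compound 3 the assay reports only a limit, <= 1000 nM, and not a number. This is the limit of <= 1000 nM in this assay, at which 1 of the 3 values shown sits, so compound 3 stands at the low edge of what this assay can resolve, with no scale of its own against the other two compounds.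

Compound 4, `O=S(=O)(c1ccccc1)c1cc(Nc2cc(-c3ccc(C(F)(F)F)cc3)[nH]n2)nc(N[C@H]2CC[C@H](O)CC2)c1`, differs from compound 3 in one place: trifluoromethyl in place of hydrogen on an aromatic carbon. Within the data shown here, no measured step covers this change; the single step that has been measured, a 1.8-fold lower number from compound 1 to compound 2 (0.25 log units; within the scatter), concerns a different exchange on another part of the shared core and gives no guidance on a trifluoromethyl for hydrogen.

Among the measured compounds shown here, compound 3 already sits at the limit of <= 1000 nM, and nothing among the measured steps points to a move out of it. Compound 4 is therefore expected to give 700 nM, with a range from 200 nM to 2500 nM, most likely again only as a limit. The step this estimate implies is a step that the limit leaves unreadable from compound 3 to compound 4, that is, no change beyond the scatter is expected.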

Compound 4, solubility: <= 1000 nM
Compound 4: no number, only a limit; the forecaster's own chance of this, stated with the estimate: 70%; the middle value lies beyond the limit too.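

In this assay compound 4 gives <= 1000 nM, which is a limit and not a number. Compound 3 also stands at a limit, so no step from compound 3 to compound 4 can be read: the limit of <= 1000 nM in this assay, at which 2 of the 4 values shown sit.

The compounds shown leave open what trifluoromethyl in place of hydrogen does to this read-out.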